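A few compounds are considered here, and "the series" means these few. Any claim that something is new, unique, unknown or untested is made for them only; others in the source may bear on it.

Compound 1 `O=C(Nc1ccc(Br)cc1CN1C(=O)c2ccc(F)cc2C1=O)c1ccccn1` gives 930 nM in an assay on CHO cells for positive allosteric modulation of metabotropic glutamate receptor 5 (Homo sapiens), read by FLIPR; a higher number here means that more compound is needed for the effect, a lower number that less compound is needed.
Compound 2 `O=C(Nc1ccc(Cl)cc1CN1C(=O)c2ccccc2C1=O)c1ccccc1` gives > 100000 nM in this assay, which is a limit of the assay and not a number.
Compound 3 `COc1ccc2c(c1OC)C(=O)N(Cc1cc(Cl)ccc1NC(=O)c1ccccn1)C2=O` gives > 100000 nM in this assay, again a limit and not a number.

Among these three measured compounds, compound 2 does not stand at any measured number: for it the assay reports only a limit, so no response was found up to the highest concentration tested. It is not alone in this, since (the limit of > 100000 nM in this assay, at which 2 of the 3 values shown sit). Only compound 1, with its different amide and its fluorine on the shared core, gives an actual value.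

The step to the unmeasured compound 4 `COc1ccccc1C(=O)Nc1ccc(Cl)cc1CN1C(=O)c2ccccc2C1=O` changes one place: methoxy in place of hydrogen on an aromatic carbon. Going by the values given here, because compound 2 sits at a limit, no measured step from it exists, and the size of the move to compound 4 cannot be read from a neighbouring pair. The expectation is that compound 4 moves downward from the limit, out of the region where nothing is seen, by a step of about an at least 5.0-fold lower number from compound 2 to compound 4 (0.69 log units; beyond the scatter), although a result that is again only a limit remains quite possible. The estimate for compound 4 in this assay is therefore 20000 nM, within a wide range from 2000 nM to 100000 nM.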

Compound 4, half-maximal effective concentration: > 100000 nM
Compound 4: no number, only a limit (the forecaster's own chance of this, stated with the estimate: 45%); middle value at least 5.0-fold (0.69 log units) from the limit.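

Compound 4 gives > 100000 nM in this assay, again a limit of the assay and not a number. Going by these compounds alone, no step from compound 2 to compound 4 can be read, because both compounds stand at the same limit: (the limit of > 100000 nM in this assay, at which 3 of the 4 values shown sit). The compounds shown leave open whether changing phenyl to 2-methoxyphenyl shifts the response in this assay at all.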